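A few compounds are considered here, and "the series" means these few. Any claim that something is new, unique, unknown or untested is made for them only; others in the source may bear on it.

Three compounds sharing one core carry different alkyl groups on the double-bonded nitrogen: compound 1 `CC(C)C/N=C(\NC#N)Nc1cccnc1`, compound 2 `CC(C)/N=C(\NC#N)Nc1cccnc1` and compound 3 `CCC(CC)/N=C(\NC#N)Nc1cccnc1`. In a functional assay on the whole organism (blood, strain Wistar-Okamoto) with Rattus norvegicus as the target, with a stated time of 5 days (on this read-out lower numbers stand for an effect already at smaller amounts and higher numbers for an effect only at larger amounts of compound), compound 1 gives 20 mg/kg, compound 2 gives 2.5 mg/kg and compound 3 gives 20 mg/kg. Compound 3 stands level with compound 1 at the digits shown, the two together at the high end of the three numbers; the step of no change at the digits printed from compound 1 to compound 3 (within the scatter) lies within the scatter, whereas an 8.0-fold higher number from compound 2 to compound 3 (0.90 log units; beyond the scatter) and an 8.0-fold lower number from compound 1 to compound 2 (0.90 log units; beyond the scatter) lie beyond it. Compound 4 `CCC(CC)(CC)/N=C(\NC#N)Nc1cccnc1` differs from compound 3 by ethyl in place of hydrogen on a saturated chain carbon bound to a double-bonded nitrogen and two saturated chain carbons. The step that bears most directly on this change is an 8.0-fold higher number from compound 2 to compound 3 (0.90 log units; beyond the scatter), where the larger group went with a higher number; no change at the digits printed from compound 1 to compound 3 (within the scatter) showed no shift at all. A further enlargement of the group is therefore expected to leave the number unchanged or raise it somewhat, so compound 4 is expected to give 30 mg/kg, within 10 mg/kg to 100 mg/kg. This corresponds to an expected step of a 1.5-fold higher number from compound 3 to compound 4 (0.18 log units; within the scatter).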

Compound 4, minimum effective dose: 1 mg/kg
The estimate for compound 4 lay 30-fold (1.48 log units) above the measured number, and the stated range ends above it.
By their numbers in this assay, from the lowest: compound 4; then compound 2; then compounds 1 and 3 (each within the scatter of the next).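

In this assay, ethyl in place of hydrogen on a saturated chain carbon bound to a double-bonded nitrogen and two saturated chain carbons gives a 20-fold lower number from compound 3 to compound 4 (1.30 log units; beyond the scatter) and so runs opposite to an 8.0-fold higher number from compound 2 to compound 3 (0.90 log units; beyond the scatter) and shows that enlarging the group on this nitrogen does not always go with a higher number. Among these compounds, group size alone therefore does not order the numbers, with compound 4 going against the trend from compound 2 to compound 3. Nothing available accounts for this reversal.

The compounds shown leave open whether methyl or a longer chain such as propyl in the same place would go the same way as ethyl. They also leave open how a cyclohexyl group on the double-bonded nitrogen would compare.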